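A few compounds are considered here, and "the series" means these few. Any claim that something is new, unique, unknown or untested is made for them only; others in the source may bear on it.

Measured compounds:
Compound 1, `Cc1ccoc1C(=O)Nc1cccc(-c2nc3ncccc3o2)c1`: 0.167 h
Compound 2, `O=C(Nc1ccc(F)c(-c2nc3ncccc3o2)c1)c1ccoc1`: 0.183 h
Compound 3, `O=C(Nc1ccc(F)c(-c2nc3ncccc3o2)c1)c1cnco1`: 2.07 h

These three share a core and were run in an ADME assay on microsomes from liver (Homo sapiens) for metabolic stability, read by LC-MS, tested at 1 uM; on this read-out higher numbers stand for a longer-lived compound and lower numbers for a shorter-lived compound. Compound 1 and compound 2 give numbers that lie within the scatter of each other, so nothing separates them on this read-out. Going by the values given here, compound 3 stands apart: the only single-point comparison among the measured compounds is an 11-fold higher number from compound 2 to compound 3 (1.05 log units; beyond the scatter), and compound 3 also sits well beyond the scatter above compound 1, whose value is the smaller of the two.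

Compound 4, `Cc1ccc(NC(=O)c2occc2C)cc1-c1nc2ncccc2o1`, differs from compound 1 in one place: methyl in place of hydrogen on an aromatic carbon. The new group is a single carbon with no ring, sitting ortho to a group of 9 heavy atoms and para to another group of 9 heavy atoms.

Among the compounds with values here, no measured step involves a methyl in place of hydrogen on an aromatic carbon. Within the data shown here, the one step that exists, an 11-fold higher number from compound 2 to compound 3 (1.05 log units; beyond the scatter), swaps the ring on the carbonyl carbon and says nothing about a change on the six-membered aromatic ring of carbon only. With no guide, the step from compound 1 to compound 4 in this assay is expected to stay within the scatter, in either direction: a 1.0-fold higher number from compound 1 to compound 4 (0.01 log units; within the scatter). Compound 4 is therefore estimated at 0.17 h, with a range from 0.08 h to 0.4 h.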

Compound 4, half-life in the Homo sapiens assay: 0.133 h
For compound 4 the middle estimate is 1.3-fold (0.11 log units) above the measured one; measured number inside the range.
By their numbers in the Homo sapiens assay, from the lowest: compounds 4, 1 and 2 (each within the scatter of the next); then compound 3.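

In the Homo sapiens assay, methyl in place of hydrogen on an aromatic carbon, ortho to one group of 9 heavy atoms and para to another, now has a measured step of its own: a 1.3-fold lower number from compound 1 to compound 4 (0.10 log units; within the scatter); compound 1 and compound 4 therefore cannot be told apart on this read-out, whereas the swap on the carbonyl carbon gave an 11-fold higher number from compound 2 to compound 3 (1.05 log units; beyond the scatter). In a physicochemical assay for solubility, read by nephelometry, in phosphate buffer, measured as kinetic solubility, at pH 6.5 (on this read-out lower numbers stand for lower solubility and higher numbers for higher solubility), compound 1 gives 3.1 ug/mL. In the physicochemical assay compound 4 gives < 1.6 ug/mL, which is a limit of the assay and not a number.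

Going by these compounds, in the physicochemical assay the printed step, an at least 1.9-fold lower number from compound 1 to compound 4 (0.28 log units; that floor lies within the scatter), is only a floor, so how far apart the two compounds lie stays open: the limit of < 1.6 ug/mL in the physicochemical assay, at which 1 of the 2 values shown sits. Also open is whether an ethyl, a methoxy group or a chlorine atom on the same aromatic carbon would read like the methyl in either assay, and whether the methyl would give a similarly small step on a compound carrying 1,3-oxazol-5-yl on the carbonyl carbon, as compound 3 does.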